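Sulfonyl Aryl Substituent Changes in an Endothelin Binding Series

A few compounds are considered here, and "the series" means these few. Any claim that something is new, unique, unknown or untested is made for them only; others in the source may bear on it.

Measured compounds:
compound 1, `Cc1ccc(-c2c(NS(=O)(=O)c3ccc(C(C)(C)C)cc3)ncnc2OCCOc2ncc(Cl)cn2)cc1`: < 0.001 nM
compound 2, `CCC(C)(C)c1ccc(S(=O)(=O)Nc2ncnc(OCCOc3ncc(Br)cn3)c2-c2ccc(C)cc2)cc1`: < 0.001 nM
compound 3, `Cc1ccc(-c2c(NS(=O)(=O)c3ccc(Br)cc3)ncnc2OCCOc2ncc(Br)cn2)cc1`: 2.8 nM

In an assay on cells (Endothelial cell) for binding affinity to Endothelin-1 receptor (Sus scrofa) (on this read-out lower numbers stand for stronger inhibition and higher numbers for weaker inhibition), compound 1 gives < 0.001 nM, which is a limit of the assay and not a number. Compound 2 in this assay also gives < 0.001 nM, again a limit. Going by the values given here, compound 3 is the only compound with a measured number, 2.8 nM in this assay, and so stands apart from the other two, which sit together at the limit of < 0.001 nM in this assay, at which 2 of the 3 values shown sit.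

Among the compounds with values here, the one measured step that touches the same position is an at least 2800-fold higher number from compound 2 to compound 3 (3.44 log units; beyond the scatter), a large loss when bromo replaces 1,1-dimethylpropyl on the aromatic carbon.

Compound 4, `Cc1ccc(-c2c(NS(=O)(=O)c3ccc(C(F)(F)F)cc3)ncnc2OCCOc2ncc(Br)cn2)cc1`, differs from compound 3 by trifluoromethyl in place of bromo on an aromatic carbon. No measured step covers bromo to trifluoromethyl directly; the single step shown only says that this position moves the number by a great deal. A modest gain is therefore expected, a 2.8-fold lower number from compound 3 to compound 4 (0.45 log units; beyond the scatter). Compound 4 is estimated to give 1 nM in this assay, with a range from 0.2 nM to 5 nM.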

Compound 4, half-maximal inhibitory concentration: 1.4 nM
Compound 4: middle estimate off by 1.4-fold (0.15 log units), on the low side; low and high end bracket the measured number.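

In this assay, trifluoromethyl and bromo at this position cannot be told apart, with a 2.0-fold lower number from compound 3 to compound 4 (0.30 log units; within the scatter). The large gap seen earlier is therefore not particular to bromo: it returns when trifluoromethyl replaces 1,1-dimethylpropyl, with an at least 1400-fold higher number from compound 2 to compound 4 (3.14 log units; beyond the scatter). This second step rests on a limit of the assay for compound 2, not on a number: the limit of < 0.001 nM in this assay, at which 2 of the 4 values shown sit.

The compounds shown leave open where an isopropyl, a cyclopropyl or a methoxy group would fall at this position, and so how the number moves over the range from trifluoromethyl to 1,1-dimethylpropyl. Going by these compounds, the true size of the gap to compound 2 also remains unknown.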